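The source may report more compounds than this note shows. Statements on the series, on what has been measured and on what is new or still open speak of the compounds shown alone.

Measured in an ADME assay on microsomes from liver (Homo sapiens) for metabolic stability, read by LC-MS, with a stated time of 10 min; on this read-out higher numbers stand for a more stable compound and lower numbers for a less stable compound:
- compound 1 `CC(C)N(C[C@H]1Cc2c(cccc2N2CCNCC2)CN1)[C@H]1CCCc2cccnc21`: 75%
- compound 2 `Cc1cnc2c(c1)CCC[C@@H]2N(C)C[C@H]1Cc2c(cccc2N2CCNCC2)CN1`: 47.8%

Compound 2 stands lowest of the two measured compounds, and its gap to compound 1 lies beyond the usual scatter. The next compound to be read is compound 3 `CN(C[C@H]1Cc2c(cccc2N2CCNCC2)CN1)[C@H]1CCCc2cccnc21`, which differs from compound 2 in one place: hydrogen in place of methyl on an aromatic carbon. In words, hydrogen stands in place of methyl on an aromatic carbon of a six-membered aromatic ring with 1 nitrogen.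

Among the measured compounds shown here, no measured pair isolates that change, so its size in this assay cannot be read from the data. For the measured compounds named here, the only reference points are compound 2 at 47.8% and compound 1 at 75%. A modest upward move is expected, placing compound 3 between these two values, although a result within the scatter of compound 2 would not be surprising. The expected step is a number 9.2 percentage points higher from compound 2 to compound 3 (within the scatter). For compound 3 the estimated value is 57%, with an expected range of 40% to 75%.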

Compound 3, percent of the compound remaining: 99.7%
The estimate for compound 3 lay 42.7 percentage points below the measured number; the whole stated range lies below it.
By their numbers in this assay, from the lowest: compound 2; then compound 1; then compound 3.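

In this assay, hydrogen in place of methyl on an aromatic carbon of the six-membered aromatic ring with 1 nitrogen gives a number 51.9 percentage points higher from compound 2 to compound 3 (beyond the scatter) and so shows that the read-out responds strongly to this single position, two atoms from the ring nitrogen and para to a fused ring. On the amine nitrogen, methyl in place of isopropyl gives a number 24.7 percentage points higher from compound 1 to compound 3 (beyond the scatter) as a modest step against that large one, and compound 3 now links both earlier compounds through single changes, with each step beyond the scatter and compound 3 highest of the three. Nothing shown here bears on why either step arises.

On these data alone, whether a larger or different group at this aromatic carbon, such as ethyl, methoxy, chlorine or a nitrile, would follow methyl or hydrogen remains open. Also open, as far as these compounds go, is whether the large step from this ring change would hold with isopropyl or a longer chain on the amine nitrogen, and whether the amine step would hold with methyl on the ring.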